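Nitro in Place of Methyl: Estimating the Next Amide

A few compounds are considered here, and "the series" means these few. Any claim that something is new, unique, unknown or untested is made for them only; others in the source may bear on it.

Three amides built on one shared core have been tested in an assay on isolated protein (Gallus gallus) for inhibition of transmembrane prolyl 4-hydroxylase (Homo sapiens); a lower number here means a stronger inhibitor, a higher number a weaker inhibitor. Compound 1 `Cc1ccc(NC(=O)c2ccc(C(=O)O)nc2)cc1` gives 8300 nM in this assay, the lowest of the three numbers. Compound 3 `COc1ccc(NC(=O)c2ccc(C(=O)O)nc2)c(OC)c1` gives 16600 nM in this assay, a number that falls within the scatter of compound 1, so the two cannot be set apart. Compound 2 `CCOc1ccccc1NC(=O)c1ccc(C(=O)O)nc1` gives 32900 nM in this assay, and its gap to compound 1 lies beyond the scatter. Within the data shown here, no two measured compounds differ in only one place, so no single-step comparison exists among them.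

Compound 4 `O=C(Nc1ccc([N+](=O)[O-])cc1)c1ccc(C(=O)O)nc1` has not been measured. It differs from compound 1 by nitro in place of methyl on an aromatic carbon. Nothing in the measured set shows what this exchange does, and the measured numbers span only a modest range with compound 1 at its low end. The expected step is a 1.2-fold lower number from compound 1 to compound 4 (0.07 log units; within the scatter), which stays within the scatter. Compound 4 is estimated at 7000 nM in this assay, with a likely range from 2000 nM to 25000 nM.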

Compound 4, half-maximal inhibitory concentration: 44000 nM
Compound 4: the middle estimate sits 6.3-fold (0.80 log units) below what was measured; the measured number lies above the stated range.
By their numbers in this assay, from the lowest: compounds 1, 3, 2 and 4 (each within the scatter of the next, the first and the last beyond it).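

In this assay, among these compounds, nitro in place of methyl on an aromatic carbon para to a large group gives a 5.3-fold higher number from compound 1 to compound 4 (0.72 log units; beyond the scatter), the first comparison in which only one place differs. It shows that this position is not indifferent to the group it carries, and that this exchange moves the number in the direction of a weaker inhibitor. No measurement available here accounts for the step.

As far as these compounds go, with a single exchange at this position, it remains open whether the weaker number is particular to nitro or would also follow from other groups on the same carbon, such as an amine, a nitrile or a trifluoromethyl group. From the compounds shown here alone, it also remains open whether the same exchange would have a similar effect on amides carrying other groups elsewhere on the ring.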